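Swapping trifluoromethyl for chloro on the arylpiperazine

This account rests on a few compounds, and the source may have more. Where it says the series, first, only, none or still open, it means among the compounds named here.

Measured so far:
compound 1 `CCCc1nc(-c2ccccc2)c(CNCCN2CCN(c3cccc(C(F)(F)F)c3)CC2)o1`: 1940 nM
compound 2 `CCCc1nc(-c2ccccc2)c(CNCCCN2CCN(c3cccc(C(F)(F)F)c3)CC2)o1`: 650 nM
compound 3 `CCCc1nc(-c2ccccc2)c(CNCCN2CCN(c3ccc(F)cc3)CC2)o1`: 7080 nM

In an assay on HEK293 cells for inhibition of Voltage-dependent T-type calcium channel subunit alpha-1G (Homo sapiens), read by patch clamp (a higher number here means a weaker inhibitor, a lower number a stronger inhibitor), compound 2 gives the lowest of the three numbers; compound 1 sits a step above it and compound 3 further still. Compound 4 `CCCc1nc(-c2ccccc2)c(CNCCCN2CCN(c3cccc(Cl)c3)CC2)o1` differs from compound 2 by chloro in place of trifluoromethyl on an aromatic carbon, which sits meta to a large group. Within the data shown here, no measured pair shows this exact exchange. Among the measured compounds shown here, the one step that touches the same aryl ring, a 3.6-fold higher number from compound 1 to compound 3 (0.56 log units; beyond the scatter), replaced the whole 3-(trifluoromethyl)phenyl with 4-fluorophenyl, a different change at a different position, so it guides only loosely. A modest weakening is therefore expected for compound 4, as a 1.8-fold higher number from compound 2 to compound 4 (0.27 log units; within the scatter). Compound 4 is estimated at 1200 nM, within 450 nM to 3500 nM.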

Compound 4, half-maximal inhibitory concentration: 1750 nM
Beside the measured number, compound 4's estimate is 1.5-fold (0.16 log units) below it; measured number inside the range.
By their numbers in this assay, from the lowest: compound 2; then compounds 4 and 1 (each within the scatter of the next); then compound 3.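

Exchanging trifluoromethyl for chloro on this aromatic carbon, with nothing else altered, gives a 2.7-fold higher number from compound 2 to compound 4 (0.43 log units; beyond the scatter) in this assay, so compound 4 is the weaker inhibitor. The group here therefore matters by itself, which the earlier step from compound 1 to compound 3 could not show, as it altered both the group and its place on the ring. Nothing measured here accounts for this loss. Still open, on these data alone, is how a methyl or methoxy group would fare at this place. Also open, as far as these compounds go, is whether the same exchange gives a similar step on the chain of compound 1.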